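Inverted Stereocentres in a Dibromobenzoyl Glycoside Series

The source may report more compounds than this note shows. Statements on the series, on what has been measured and on what is new or still open speak of the compounds shown alone.

Compound 1 `CC(C)[C@H]1CC[C@H](C)C[C@@H]1O[C@@H]1O[C@H](CO[C@@H]2O[C@H](COC(=O)c3ccc(Br)cc3)[C@@H](OC(=O)c3ccc(Br)cc3)[C@H](O)[C@H]2O)[C@@H](O)[C@H](O)[C@H]1O` and compound 2 `CC(C)[C@@H]1CC[C@@H](C)C[C@H]1O[C@@H]1O[C@H](CO[C@@H]2O[C@H](COC(=O)c3ccc(Br)cc3)[C@@H](OC(=O)c3ccc(Br)cc3)[C@H](O)[C@H]2O)[C@@H](O)[C@H](O)[C@H]1O` share every atom and bond and differ only in configuration. In a functional assay on HL-60 cells (Homo sapiens) for cytotoxicity, read by MTT assay, with a stated time of 72 h (on this read-out higher numbers stand for weaker inhibition and lower numbers for stronger inhibition), compound 1 gives 14900 nM and compound 2 gives 7000 nM, the lowest of the two numbers; the step of a 2.1-fold lower number from compound 1 to compound 2 (0.33 log units; beyond the scatter) rests on (the fact that compounds 1 and 2 differ only in the configuration as drawn). Compound 3 `CC(C)[C@H]1CC[C@H](C)C[C@@H]1O[C@H]1O[C@H](CO[C@@H]2O[C@H](COC(=O)c3ccc(Br)cc3)[C@@H](OC(=O)c3ccc(Br)cc3)[C@H](O)[C@H]2O)[C@@H](O)[C@H](O)[C@H]1O` again keeps the same atoms and bonds: the two compounds have the same atoms and bonds and differ only in configuration as drawn: 4 of 13 stereo elements differ; a stereocentre at a saturated ring carbon is drawn S in compound 2 and R in compound 3; a stereocentre at a saturated ring carbon is drawn R in compound 2 and S in compound 3; a stereocentre at a saturated ring carbon is drawn R in compound 2 and S in compound 3; a stereocentre at a saturated ring carbon is drawn R in compound 2 and S in compound 3. Because compound 1 gave 14900 nM with the ring centres drawn as in compound 3, a return toward that higher number is expected, with the fourth centre adding uncertainty. Compound 3 is therefore expected to give 12000 nM, between 5000 nM and 30000 nM, a step of a 1.7-fold higher number from compound 2 to compound 3 (0.23 log units; within the scatter).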

Compound 3, half-maximal inhibitory concentration: 7300 nM
Compound 3: the middle estimate sits 1.6-fold (0.22 log units) above what was measured; the range from low to high includes it.
By their numbers in this assay, from the lowest: compounds 2 and 3 (each within the scatter of the next); then compound 1.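

In this assay, a single inverted stereocentre at a saturated ring carbon gives a 2.0-fold lower number from compound 1 to compound 3 (0.31 log units; beyond the scatter), so one centre alone is enough to move the number beyond the scatter: the fact that compounds 1 and 3 differ only in the configuration as drawn. Four inverted centres give a 1.0-fold higher number from compound 2 to compound 3 (0.02 log units; within the scatter), so among these compounds, more inverted centres do not mean a larger step: the fact that compounds 2 and 3 differ only in the configuration as drawn.

On these data alone, what each of the other centres does alone stays open, since compound 2 differs from compound 1 and compound 3 at several centres at once. Also open, as far as these compounds go, is whether the single inversion has the same effect with an amine on the shared core.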